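Lengthening the amine tether in a chalcone series

A few compounds are considered here, and "the series" means these few. Any claim that something is new, unique, unknown or untested is made for them only; others in the source may bear on it.

Among the measured compounds shown here, compound 1 `CN(C)CCCOc1ccc(C(=O)/C=C/c2ccccc2)cc1` is the most polar of the three measured members: in a physicochemical assay for lipophilicity, using the shake flask method, measured as octanol-water partition, at pH 7.4 (a lower number here means a more polar compound, a higher number a more lipophilic compound), compound 1 gives 1.59. Compound 2 `CCCN(CCC)CCCCOc1ccc(C(=O)/C=C/c2ccccc2)cc1` gives 1.95 and compound 3 `CCCCN(CCCC)CCCCOc1ccc(C(=O)/C=C/c2ccccc2)cc1` gives 2.09. The two steps away from compound 1 are both modest but real, a number 0.36 log units higher from compound 1 to compound 2 (beyond the scatter) and a number 0.50 log units higher from compound 1 to compound 3 (beyond the scatter), while the step of a number 0.14 log units higher from compound 2 to compound 3 (within the scatter) stays within the scatter.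

Compound 4 `CN(C)CCCCCOc1ccc(C(=O)/C=C/c2ccccc2)cc1` is not yet measured. Its difference from compound 1 is 2-(dimethylamino)ethyl in place of dimethylamino on a saturated chain carbon, three bonds along the chain from an oxygen on an aromatic ring, so the chain between the oxygen on the aromatic ring and the nitrogen grows by two saturated carbons rather than the substituents on the nitrogen itself. For the measured compounds named here, no measured step reproduces this change exactly. The nearest guidance is that adding carbons on the nitrogen raised the partition coefficient modestly, as seen in a number 0.36 log units higher from compound 1 to compound 2 (beyond the scatter), and that a further two carbons gave a number 0.14 log units higher from compound 2 to compound 3 (within the scatter). Two added chain carbons are therefore expected to move compound 4 upward by a small to modest amount, estimated as a number 0.31 log units higher from compound 1 to compound 4 (beyond the scatter). Compound 4 is accordingly expected to show 1.9 in this assay, with a range from 1.6 to 2.25.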

Compound 4, partition coefficient: 1.73
For compound 4 the middle estimate is 0.17 log units above the measured one; measured number inside the range.
By their numbers in this assay, from the lowest: compounds 1, 4, 2 and 3 (each within the scatter of the next, the first and the last beyond it).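

Extending the chain at this saturated chain carbon, with 2-(dimethylamino)ethyl in place of dimethylamino, leaves the nitrogen substituents unchanged and does not clearly separate the two compounds in this assay, where the step is a number 0.14 log units higher from compound 1 to compound 4 (within the scatter). Set against the compounds carrying the longer groups on nitrogen, the result divides: the comparison gives a number 0.22 log units lower from compound 2 to compound 4 (within the scatter), but also a number 0.36 log units lower from compound 3 to compound 4 (beyond the scatter), so only the dibutylamino compound stands clearly apart from the chain-extended dimethylamino compound in this assay. No supporting measurement is available to explain why these steps take the sizes they do.

The compounds shown leave open whether a longer chain still, such as 5-(dimethylamino)pentyl, would move the partition coefficient beyond the scatter from compound 1, and whether the same chain extension would behave alike with dipropylamino or dibutylamino on the nitrogen. They also leave open how a cyclic amine such as piperidine or morpholine would compare with these open-chain amines at the end of the tether.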